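Swapping bromo for cyano on a second core

The compounds below may be only part of what the source reports. "The series", "measured", "known", "first", "only" and "open" are said of these compounds alone.

Compound 1 `COc1cc([C@](O)(CCN(C)C)[C@@H](c2cc3cc(Br)ccc3nc2OC)c2ccnc(OC)c2OC)cc(OC(F)F)n1` was examined in an ADME assay on the whole organism (Mus musculus, strain CD-1) for pharmacokinetics, at a dose of 10 mg/kg by the oral route (a higher number here means that a larger share of the oral dose reaches the circulation, a lower number that a smaller share of the oral dose reaches the circulation), where compound 1 gives 50%. Compound 2 `COc1cc([C@](O)(CCN(C)C)[C@@H](c2cc3cc(C#N)ccc3nc2OC)c2ccnc(OC)c2OC)cc(OC(F)F)n1` carries the change cyano in place of bromo on an aromatic carbon on the core of compound 1; in this assay compound 2 gives 43%, and the step of a number 7 percentage points lower from compound 1 to compound 2 (within the scatter) is small. Compound 3 `COc1cc([C@](O)(CCN(C)C)[C@@H](c2cc3cc(Br)ccc3nc2OC)c2cccc(OC)c2F)cc(SC)n1` has a different core; the difference between the two cores is not broken down here. In this assay compound 3 gives 31%, the lowest of the three numbers, and its gaps to compound 2 and to compound 1 lie beyond the scatter.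

Compound 4 `COc1cc([C@](O)(CCN(C)C)[C@@H](c2cc3cc(C#N)ccc3nc2OC)c2cccc(OC)c2F)cc(SC)n1` has not yet been measured. Among the measured compounds shown here, it differs from compound 3 by cyano in place of bromo on an aromatic carbon, which is the same change as the one that takes compound 1 to compound 2, at the same place. Compound 4 is therefore expected to show a step of a number 5 percentage points lower from compound 3 to compound 4 (within the scatter), resting on the measured step of a number 7 percentage points lower from compound 1 to compound 2 (within the scatter) for the same change. On that basis compound 4 is estimated to give 26% in this assay, with a range from 12% to 42% expected.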

Compound 4, oral bioavailability: 28%
Compound 4: middle estimate off by 2 percentage points, on the low side, and the stated range covers the measured number.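

In this assay, cyano in place of bromo on an aromatic carbon gives a number 3 percentage points lower from compound 3 to compound 4 (within the scatter), so the change behaves on this second core as it did on the first. Set side by side, the two steps show no difference between the cores: the same change on two cores in this assay, a number 7 percentage points lower (within the scatter) from compound 1 to compound 2 and a number 3 percentage points lower (within the scatter) from compound 3 to compound 4, 4 percentage points apart, within the scatter of two such steps. This shows that, on these two cores only, the exchange leaves the number within the scatter; it does not establish a real fall on either core, it does not show that the same would hold on any further core, and it gives no reason for the outcome.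

The compounds shown carry only bromo or cyano at this place, so it remains open how a chloro group, an amine or a carboxylic acid there would read in this assay. It also remains open which of the several differences between the two cores bears on the numbers, since no pair shown isolates any one of them.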